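Replacing the 3-methoxyphenyl arm of compound 3: compound 4

The compounds below may be only part of what the source reports. "The series", "measured", "known", "first", "only" and "open" are said of these compounds alone.

Three members of the series carry numbers in a functional assay on PC-3 cells (Homo sapiens) for cytotoxicity, with a stated time of 48 h; on this read-out lower numbers stand for stronger inhibition and higher numbers for weaker inhibition. Compound 1 `COc1ccc(-c2cc(COC(Cc3cn(C4CCN(Cc5ccc([N+](=O)[O-])cc5)CC4)nn3)c3ccc(Br)cc3)on2)cc1` gives 3000 nM and compound 2 `N#Cc1ccc(-c2cc(COC(Cc3cn(C4CCN(Cc5ccc([N+](=O)[O-])cc5)CC4)nn3)c3ccc(Br)cc3)on2)cc1` gives 2000 nM. Compound 3 `COc1cccc(-c2cc(COC(Cc3cn(C4CCN(Cc5ccc([N+](=O)[O-])cc5)CC4)nn3)c3ccc(Br)cc3)on2)c1` gives only > 25000 nM, which is a limit of this assay and not a number. Compound 3 therefore sits at the limit of > 25000 nM in this assay, at which 1 of the 3 values shown sits, the weak end of what has been measured.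

Among the steps, cyano in place of methoxy on an aromatic carbon gave a 1.5-fold lower number from compound 1 to compound 2 (0.18 log units; within the scatter). Moving to the 3-methoxyphenyl arm cost more: an at least 8.3-fold higher number from compound 1 to compound 3 (0.92 log units; beyond the scatter) and an at least 12-fold higher number from compound 2 to compound 3 (1.09 log units; beyond the scatter).

Compound 4 `O=[N+]([O-])c1ccc(CN2CCC(n3cc(CC(OCc4cc(-c5ccccc5Br)no4)c4ccc(Br)cc4)nn3)CC2)cc1` differs from compound 3 by 2-bromophenyl in place of 3-methoxyphenyl on an aromatic carbon. For the measured compounds named here, no measured step exchanges one of these arms for a 2-bromophenyl, so the steps from compounds 1 and 2 only show that the 3-methoxyphenyl arm of compound 3 is the least favourable arm seen, while both four-substituted arms sit within the scatter of each other. For compound 4 the change leaves the 3-methoxyphenyl arm, and the direction is open; the expected step in this assay is an at least 2.0-fold lower number from compound 3 to compound 4 (0.31 log units; beyond the scatter). Compound 4 is thus estimated at 12000 nM, with a range from 2500 nM to 30000 nM.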

Compound 4, half-maximal inhibitory concentration: > 25000 nM
Compound 4 ended at the assay's limit; the forecaster's own chance of this, stated with the estimate: 40%; at least 2.0-fold (0.31 log units) between middle value and limit.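

In this assay, the 2-bromophenyl arm, on the aromatic carbon next to the ring nitrogen, falls on the weak side alongside the 3-methoxyphenyl arm: an at least 12-fold higher number from compound 2 to compound 4 (1.09 log units; beyond the scatter), and an at least 8.3-fold higher number from compound 1 to compound 4 (0.92 log units; beyond the scatter). The loss at this position is therefore no longer tied to the 3-methoxyphenyl arm alone, and among the four arms shown, only the 4-methoxyphenyl of compound 1 and the 4-cyanophenyl of compound 2 give readable numbers. The step between the 3-methoxyphenyl arm of compound 3 and the 2-bromophenyl arm of compound 4 cannot be read, since both compounds give only a limit and not a number: the limit of > 25000 nM in this assay, at which 2 of the 4 values shown sit.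

From the compounds shown here alone, it stays open whether these two arms differ from each other at all, and how weak either one really is. Going by these compounds, it is also open whether the loss follows the place of the substituent on the phenyl ring or the substituent itself: a 4-bromophenyl or a 3-cyanophenyl arm would separate the two, and an unsubstituted phenyl would give a plain reference for the series.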